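The compounds below may be only part of what the source reports. "The series", "measured", "known", "first", "only" and "open" are said of these compounds alone.

Measured compounds:
Compound 1, `Nc1cc(-c2ccccc2)ccc1Cn1cncc1CNc1ccc(-c2cncs2)c(-c2ccccc2)c1`: in a toxicity assay on NIH3T3 cells (Mus musculus) for cytotoxicity, read by resazurin assay (a lower number here means that less compound is needed, a higher number that more compound is needed for the effect), compound 1 gives > 1000 nM, which is a limit of the assay.
Compound 2, `COC(=O)c1ccc(NCc2cncn2Cc2ccc(N)cc2)cc1-c1ccccc1`: in this assay compound 2 gives > 10000 nM, also a limit.
Compound 3, `O=C(c1ccc(NCc2cncn2Cc2ccc(-c3ccccc3)cc2)cc1-c1ccccc1)N1CCCCC1`: in this assay compound 3 gives > 1000 nM, again a limit.

None of the three compounds yields a number in this assay; every value is a limit. Compound 2 stands at the limit of > 10000 nM in this assay, at which 1 of the 3 values shown sits, while the other two compounds sit at the limit of > 1000 nM in this assay, at which 2 of the 3 values shown sit. Among the measured compounds shown here, no pair of measured compounds differs in a single place, so no measured step is available to lean on.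

Compound 4, `COC(=O)c1ccc(NCc2cncn2Cc2cccc(C#N)c2)cc1-c1ccccc1`, differs from compound 2 by 3-cyanophenyl in place of 4-aminophenyl on a saturated chain carbon bound to an aromatic nitrogen.

For the measured compounds named here, with compound 2 already at a limit and no measured step to guide the change, the expected step is a step that the limit leaves unreadable from compound 2 to compound 4, which lies within the usual scatter of this kind of measurement. For compound 4 in this assay the estimate is 15000 nM, with a range from 4000 nM to 50000 nM, and it is expected that the assay will most likely again report only a limit rather than a number.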

Compound 4, half-maximal effective concentration: > 10000 nM
Compound 4: no number, only a limit (the forecaster's own chance of this, stated with the estimate: 80%); the middle value lies beyond the limit too.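

Compound 2 and compound 4 each give only a limit in this assay, so the step between them cannot be read. The compounds shown leave open how much of any of them is needed for the effect in this assay, and whether replacing 4-aminophenyl with 3-cyanophenyl changes that amount.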